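This account rests on a few compounds, and the source may have more. Where it says the series, first, only, none or still open, it means among the compounds named here.

Measured compounds:
compound 1 `N#Cc1c(Nc2cccc(C(F)(F)F)c2)nc(SCc2cn(Cc3ccccc3Cl)nn2)nc1-c1ccccc1` — in a functional assay on B16-F10 cells (Mus musculus) for inhibition, read by MTT assay, with a stated time of 72 h (a lower number here means a stronger inhibitor, a higher number a weaker inhibitor), compound 1 gives 3710 nM
compound 2 `Cc1ccc(Nc2nc(SCc3cn(Cc4ccccc4Cl)nn3)nc(-c3ccccc3)c2C#N)cc1` — in this assay compound 2 gives 3390 nM

For the measured compounds named here, compound 2 stands at the lowest of the two numbers known so far, but only just: its nearest neighbour is compound 1, and the single measured step, a 1.1-fold lower number from compound 1 to compound 2 (0.04 log units; within the scatter), lies within the scatter, so the two compounds cannot be told apart on these data.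

Compound 3 `Cc1ccc(Nc2nc(SCc3cn(Cc4ccccc4Cl)nn3)nc(-c3ccc(C(C)C)cc3)c2C#N)cc1` differs from compound 2 in one place: isopropyl in place of hydrogen on an aromatic carbon. Going by the values given here, the only measured step, a 1.1-fold lower number from compound 1 to compound 2 (0.04 log units; within the scatter), concerns the aryl group on the nitrogen, not the phenyl on the shared core, so no measured step bears directly on this change. With nothing to indicate a direction, the expectation is that the step of a 1.1-fold lower number from compound 2 to compound 3 (0.05 log units; within the scatter) will be small, and most likely within the scatter of this assay. Compound 3 is therefore estimated at 3000 nM in this assay, with a range from 1000 nM to 9000 nM to allow for the absence of any directly comparable step.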

Compound 3, half-maximal inhibitory concentration: 3530 nM
Compound 3: middle estimate off by 1.2-fold (0.07 log units), on the low side; measured number inside the range.
By their numbers in this assay, from the lowest: compounds 2, 3 and 1 (each within the scatter of the next).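

In this assay, for the compounds shown here, the move from phenyl to 4-isopropylphenyl on the shared core is a 1.0-fold higher number from compound 2 to compound 3 (0.02 log units; within the scatter) and gives the first measured step at this position, where the earlier compounds carried only the unsubstituted phenyl. It shows that a group of 3 carbon atoms, with no ring and no hydrogen-bond donors or acceptors, can stand on this aromatic carbon, para to a large group, while compound 3 remains indistinguishable from compound 2 in this read-out. The step on the nitrogen's aryl group, a 1.1-fold lower number from compound 1 to compound 2 (0.04 log units; within the scatter), and this one on the phenyl both lie within the scatter, so neither of the two single changes shown so far separates its pair, and nothing available speaks to the reason for this result.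

What the compounds shown leave open is whether this position stays as undiscriminating with a different kind of group, such as an amine, a carboxylic acid or a longer alkyl chain, in place of isopropyl. With one substituent at one place on this phenyl, they also leave open whether a methoxy group or a chlorine atom on the same carbon would give a step beyond the scatter.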